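This account rests on a few compounds, and the source may have more. Where it says the series, first, only, none or still open, it means among the compounds named here.

Measured in an ADME assay for permeability, using PAMPA, at pH 7.4; a lower number here means that the compound crosses the layer more slowly, a higher number that the compound crosses the layer faster:

compound 1 `Cn1cc(-c2ccc(C(F)(F)F)cc2)c2cc(F)c(C(=O)NS(=O)(=O)C3CC3)cc21`: 323 nm/s
compound 2 `CC(C)COc1ccc(-c2cn(C)c3cc(C(=O)NS(C)(=O)=O)c(F)cc23)cn1`: 164 nm/s
compound 3 `Cn1cc(-c2ccc(C(F)(F)F)cc2)c2cc(F)c(C(=O)NS(C)(=O)=O)cc21`: 140 nm/s

Compound 1 and compound 3 share a core; compound 2 stands on a different core, and the difference between the two cores is not broken down here. Within the first core, the change cyclopropyl in place of methyl on a sulfonyl sulfur gave a 2.3-fold higher number from compound 3 to compound 1 (0.36 log units; beyond the scatter) in this assay. Compound 4 `CC(C)COc1ccc(-c2cn(C)c3cc(C(=O)NS(=O)(=O)C4CC4)c(F)cc23)cn1` carries the same change on the core of compound 2: cyclopropyl in place of methyl on a sulfonyl sulfur. Among the measured compounds shown here, the place of the change is the same in both pairs, so the step from compound 3 to compound 1 is the only guide, and it rests on one pair alone. In this assay, compound 4 is expected to show a 2.3-fold higher number from compound 2 to compound 4 (0.35 log units; beyond the scatter) over compound 2, because compound 2 gives 164 nm/s and compound 1 gives 323 nm/s after the same change. Compound 4 is therefore estimated at 370 nm/s, expected to lie between 200 nm/s and 700 nm/s.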

Compound 4, apparent permeability: 254 nm/s
Compound 4: middle estimate off by 1.5-fold (0.16 log units), on the high side; the measured number falls inside the stated range.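

On the core of compound 2, cyclopropyl in place of methyl on a sulfonyl sulfur gave a 1.5-fold higher number from compound 2 to compound 4 (0.19 log units; within the scatter) in this assay, so on this core the change alone is not resolved from the scatter. Set beside the step on the other core, the two readings do not differ: the same change on two cores in this assay, a 2.3-fold higher number (0.36 log units; beyond the scatter) from compound 3 to compound 1 and a 1.5-fold higher number (0.19 log units; within the scatter) from compound 2 to compound 4, 1.5-fold (0.17 log units) apart, within the scatter of two such steps

The change therefore shows no dependence on core across these two pairs, but two pairs, one of them within the scatter, do not establish a fixed step that holds on further cores.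

The compounds shown leave open whether a longer chain, such as n-butyl, or a phenyl ring on the sulfonyl sulfur would follow the same course. Also open, going by these compounds, is how a dimethylamino group in that place would read in this assay.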